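A Methoxy Addition Tested on a Weaker Amide Core

This account rests on a few compounds, and the source may have more. Where it says the series, first, only, none or still open, it means among the compounds named here.

Measured so far in a functional assay on HepG2 cells (Homo sapiens) for antiproliferative activity, read by sulforhodamine B assay, with a stated time of 48 h; on this read-out higher numbers stand for weaker inhibition and lower numbers for stronger inhibition:
compound 1, `COc1ccc(C(=O)/C=C/c2ccccc2-c2ccc(F)cc2)cc1OC`, gives 6600 nM;
compound 2, `COc1cc(C(=O)/C=C/c2ccccc2-c2ccc(F)cc2)cc(OC)c1OC`, gives 12000 nM;
compound 3, `COc1ccc(CNC(=O)c2ccccc2-c2ccc(F)cc2)cc1`, reaches only a limit of this assay, > 50000 nM.

Compound 1 and compound 2 share one core, and the step between them is methoxy in place of hydrogen on an aromatic carbon. In this assay that step is a 1.8-fold higher number from compound 1 to compound 2 (0.26 log units; within the scatter), so the two values cannot be told apart. Compound 3 has a different core; how its core differs from that of compound 1 is not broken down here. Its value is a limit, where (the limit of > 50000 nM in this assay, at which 1 of the 3 values shown sits), and no number is known for it.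

Compound 4, `COc1ccc(CNC(=O)c2ccccc2-c2ccc(F)cc2)cc1OC`, is still unmeasured. It arises from compound 3 by methoxy in place of hydrogen on an aromatic carbon. This is the same kind of change as from compound 1 to compound 2, though there the place was also meta to a methoxy group. Because a 1.8-fold higher number from compound 1 to compound 2 (0.26 log units; within the scatter), the expected step is small: a step that the limit leaves unreadable from compound 3 to compound 4. Compound 4 is therefore estimated at 70000 nM, most likely again only a limit, with a range from 25000 nM to 250000 nM.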

Compound 4, half-maximal inhibitory concentration: > 50000 nM
Compound 4 was reported as a limit (the forecaster's own chance of this, stated with the estimate: 85%); the middle value is on the limit's open side.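

Compound 3 and compound 4 both stand at a limit of this assay rather than at a number, so no step between them can be read: the limit of > 50000 nM in this assay, at which 2 of the 4 values shown sit.

The compounds shown leave open whether methoxy in place of hydrogen on an aromatic carbon changes antiproliferative activity at all on the core of compound 3.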